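This account rests on a few compounds, and the source may have more. Where it says the series, first, only, none or still open, it means among the compounds named here.

Compound 1 `CC(=O)N1CC2CC1CN2Cc1cc2ccc(Oc3nc4cnccc4s3)cc2o1` gives 2370 nM in an in vitro assay on Sf9 cells for inhibition of leukotriene A-4 hydrolase (Homo sapiens), read by immunoassay, with stated times of 10 min and 30 min; on this read-out lower numbers stand for stronger inhibition and higher numbers for weaker inhibition. Compound 2 `CC(=O)N1CC2CC1CN2Cc1cc2ccc(Oc3nc4cccnc4s3)cc2o1` differs from it by a group of 9 heavy atoms (6 carbon, 2 nitrogen, 1 sulfur; one five-membered aromatic ring with 2 hetero atoms, one six-membered aromatic ring with 1 hetero atom) in place of a group of 9 heavy atoms (6 carbon, 2 nitrogen, 1 sulfur; one five-membered aromatic ring with 2 hetero atoms, one six-membered aromatic ring with 1 hetero atom), on an oxygen on an aromatic ring, and in this assay compound 2 gives 2130 nM, so the step of a 1.1-fold lower number from compound 1 to compound 2 (0.05 log units; within the scatter). Compound 3 `CC(=O)N1CC2CC1CN2Cc1coc2cc(Oc3nc4cnccc4s3)ccc12` gives 340 nM in this assay, the lowest number of the three; the difference between the core of compound 3 and the core of compound 1 is not broken down here, and the two values simply show compound 3 well beyond the scatter from both compound 1 and compound 2. Compound 4 `CC(=O)N1CC2CC1CN2Cc1coc2cc(Oc3nc4cccnc4s3)ccc12` has not yet been measured. It differs from compound 3 by a group of 9 heavy atoms (6 carbon, 2 nitrogen, 1 sulfur; one five-membered aromatic ring with 2 hetero atoms, one six-membered aromatic ring with 1 hetero atom) in place of a group of 9 heavy atoms (6 carbon, 2 nitrogen, 1 sulfur; one five-membered aromatic ring with 2 hetero atoms, one six-membered aromatic ring with 1 hetero atom), on an oxygen on an aromatic ring, the same change that carries compound 1 to compound 2. On the core of compound 1 that change made a step within the scatter, so the expected step of a 1.1-fold lower number from compound 3 to compound 4 (0.04 log units; within the scatter) is small as well, resting only on a 1.1-fold lower number from compound 1 to compound 2 (0.05 log units; within the scatter). For compound 4 in this assay the expected value is therefore 310 nM, with a likely range from 150 nM to 650 nM.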

Compound 4, half-maximal inhibitory concentration: 300 nM
Compound 4: the middle estimate sits 1.0-fold (0.01 log units) above what was measured; the range from low to high includes it.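

In this assay the exchange of one group for the other on the oxygen gives a 1.1-fold lower number from compound 3 to compound 4 (0.05 log units; within the scatter), and the comparison with the earlier step shows that the two cores behave alike: the same change on two cores in this assay, a 1.1-fold lower number (0.05 log units; within the scatter) from compound 1 to compound 2 and a 1.1-fold lower number (0.05 log units; within the scatter) from compound 3 to compound 4, 1.0-fold (0.01 log units) apart, within the scatter of two such steps Within these four compounds, then, the change carries from one core to the other without a readable step, and the two pairs agree in showing none. This does not show that the change would stay this small on any further core, and since neither step stands out from the scatter, the agreement is between two null results and says nothing about a change with a step large enough to read.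

The compounds shown leave open how a different group on that oxygen, such as a plain phenyl ring or a longer alkyl chain, would read in this assay. They also leave open whether an amine or a carboxylic acid in place of the group on the other end of the shared core would alter the picture.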